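The source may report more compounds than this note shows. Statements on the series, on what has been measured and on what is new or still open speak of the compounds shown alone.

Of the compounds shown here, three have been measured in a functional assay with Cavia porcellus as the target; on this read-out lower numbers stand for stronger inhibition and higher numbers for weaker inhibition. Compound 1 `C=C(C)C[N+](C)(C)c1ccc(O)cc1` gives > 3000 nM in this assay, which is a limit of the assay rather than a number. Compound 2 `C[N+](C)(Cc1ccccc1)c1ccccc1O` likewise gives > 3000 nM in this assay, again only a limit. Compound 3 `COc1ccc([N+](C)(C)Cc2ccccc2)cc1` gives > 3000 nM in this assay, also a limit. Within the data shown here, all three sit at the limit of > 3000 nM in this assay, at which 3 of the 3 values shown sit, so compound 2 stands where every value so far stands, with no number of its own that would set it apart from the others. Compound 4 `CC(=O)Oc1ccccc1[N+](C)(C)Cc1ccccc1` has not yet been measured; it differs from compound 2 by acetyl in place of hydrogen on an oxygen on an aromatic ring, hydroxy becoming acetoxy. Among the measured compounds shown here, no step between measured compounds exists to show what such a change does in this assay. With compound 2 at a limit, the expected step is a step that the limit leaves unreadable from compound 2 to compound 4, none beyond the scatter. Compound 4 is therefore estimated at 5000 nM, between 2000 nM and 20000 nM, with this assay likely to report only a limit again.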

Compound 4, half-maximal inhibitory concentration: > 3000 nM
Compound 4: a limit, no number; the forecaster's own chance of this, stated with the estimate: 80%; the middle value lies beyond the limit too.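

Compound 2 and compound 4 both give only a limit and not a number, so no step can be read between them. The compounds shown leave open what hydroxy becoming acetoxy does to the read-out, and what number any of these compounds would have.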